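The source may hold more compounds than are shown below. What is called first, only, known or untested is meant among the compounds shown, and "the series" means these compounds.

Measured so far in a functional assay on CHO-K1 cells for antagonist activity at melanin-concentrating hormone receptor 1 (Homo sapiens), read by inositol phosphate accumulation; on this read-out lower numbers stand for stronger inhibition and higher numbers for weaker inhibition:
compound 1 `Cc1nc(N2CCN(C3CCCC3)CC2)nc2ccc(NC(=O)COc3ccc(Cl)cc3)cc12`: 150 nM
compound 2 `Cc1nc(N2CCN(S(C)(=O)=O)CC2)nc2ccc(NC(=O)COc3ccc(Cl)cc3)cc12`: compound 2 sits at the assay limit, > 10000 nM
compound 3 `Cc1nc(N2CCN(C)CC2)nc2ccc(NC(=O)COc3ccc(Cl)cc3)cc12`: 3800 nM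

Compound 3 gives the highest number among the measured values; the nearest is compound 1, with a 25-fold higher number from compound 1 to compound 3 (1.40 log units; beyond the scatter). The other value is a limit only (the limit of > 10000 nM in this assay, at which 1 of the 3 values shown sits).

Compound 4 `CCC1(O)CCN(c2nc(C)c3cc(NC(=O)COc4ccc(Cl)cc4)ccc3n2)CC1` carries 4-ethyl-4-hydroxypiperidin-1-yl in place of 4-methylpiperazin-1-yl on an aromatic carbon. Among the measured compounds shown here, two measured steps bear on this. Trading cyclopentyl for methyl on the ring amine gave a 25-fold higher number from compound 1 to compound 3 (1.40 log units; beyond the scatter), so a larger group on that ring is tolerated and helps. Trading cyclopentyl for methylsulfonyl gave an at least 66-fold higher number from compound 1 to compound 2 (1.82 log units; beyond the scatter), and compound 2 to compound 3 gave an at least 2.6-fold lower number from compound 2 to compound 3 (0.42 log units; beyond the scatter). Compound 4 brings a bulkier group but loses the ring nitrogen of the piperazine, so the expected change is modest, in either direction, a 1.5-fold lower number from compound 3 to compound 4 (0.18 log units; within the scatter). Compound 4 is expected at 2500 nM, within 400 nM to 10000 nM.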

Compound 4, half-maximal inhibitory concentration: 384 nM
Estimate against measurement, compound 4: 6.5-fold (0.81 log units) above, outside the stated range (below it).
By their numbers in this assay, from the lowest: compound 1; then compound 4; then compound 3. At a limit, above all of these: compound 2.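

The second ring nitrogen of the piperazine is not required at this position: 4-ethyl-4-hydroxypiperidin-1-yl in place of 4-methylpiperazin-1-yl gives a 9.9-fold lower number from compound 3 to compound 4 (1.00 log units; beyond the scatter). The new group does not fully match 4-cyclopentylpiperazin-1-yl, with a 2.6-fold higher number from compound 1 to compound 4 (0.41 log units; beyond the scatter). Against 4-(methylsulfonyl)piperazin-1-yl the step is an at least 26-fold lower number from compound 2 to compound 4 (1.41 log units; beyond the scatter), a bound only, as compound 2 is a limit: the limit of > 10000 nM in this assay, at which 1 of the 4 values shown sits.

Open, on these data alone, is whether the hydroxyl or the ethyl carries the gain; 4-hydroxypiperidin-1-yl or 4-ethylpiperidin-1-yl would separate them. Also open, as far as these compounds go, is how an amine or a carboxylic acid in place of the hydroxyl would read.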